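The source may report more compounds than this note shows. Statements on the series, on what has been measured and on what is new or still open speak of the compounds shown alone.

Working notes on the series. Of the compounds shown here, two have been measured in an assay on CHO cells for inhibition of metabotropic glutamate receptor 1 (Rattus norvegicus); a higher number here means a weaker inhibitor, a lower number a stronger inhibitor. Compound 1 `CCCOC(=O)c1[nH]c(COC(C)=O)c(C(=O)OC(C)(C)C)c1C` gives 2700 nM in this assay. Compound 2 `Cc1c(C(=O)OC(C)(C)C)c[nH]c1C(=O)Sc1ccccn1` gives 3000 nM in this assay. These two numbers sit within the usual scatter of each other, so no order between compound 1 and compound 2 can be read from them; compound 1 is simply one of two values at the same level. Among the compounds with values here, compound 2 and compound 1 differ in more than one place, so no single step is recorded between them.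

The next compound, compound 3 `CCCOC(=O)c1[nH]c(C(=O)Sc2ccccn2)c(C(=O)OC(C)(C)C)c1C`, is reached from compound 1 by one change: ((pyridin-2-yl)sulfanyl)carbonyl in place of acetoxymethyl on an aromatic carbon. The entering group is the same ((pyridin-2-yl)sulfanyl)carbonyl that compound 2 carries on the shared core, and compound 2 with that group sits at 3000 nM, at the level of compound 1.

Expectation: because compound 2 shows 3000 nM with the entering group in place, the step from compound 1 to compound 3 is expected to stay within the scatter, as a 1.0-fold lower number from compound 1 to compound 3 (0.02 log units; within the scatter). Compound 3 is estimated at 2600 nM, with a range from 900 nM to 7500 nM.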

Compound 3, half-maximal inhibitory concentration: 3200 nM
The estimate for compound 3 lay 1.2-fold (0.09 log units) below the measured number; low and high end bracket the measured number.
By their numbers in this assay, from the lowest: compounds 1, 2 and 3 (each within the scatter of the next).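

In this assay, the exchange of acetoxymethyl for ((pyridin-2-yl)sulfanyl)carbonyl gives a 1.2-fold higher number from compound 1 to compound 3 (0.07 log units; within the scatter). Within the data shown here, this is the first single-place comparison, and it shows that, on this aromatic carbon next to the ring nitrogen, the two groups cannot be told apart by their numbers, although the entering group is larger and brings a six-membered aromatic ring. Nothing at hand accounts for this level across the two compounds.

What the compounds shown leave open is whether any group at this position can move the number beyond the scatter, for instance a small amine, a free carboxylic acid or a simple longer alkyl chain in place of the ((pyridin-2-yl)sulfanyl)carbonyl group. Also open, as far as these compounds go, is how much the tert-butoxycarbonyl and propoxycarbonyl groups contribute, since both stay unchanged in this step, and whether a carboxylic acid or an amide in place of either one would shift the level of the series.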